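Aryl hydroxyphenyl swap on the acetylpiperazine cyclobutyl series

This account rests on a few compounds, and the source may have more. Where it says the series, first, only, none or still open, it means among the compounds named here.

Measured compounds in a functional assay on BaF3 cells (Mus musculus) for antiproliferative activity, with a stated time of 48 h; a higher number here means a weaker inhibitor, a lower number a stronger inhibitor:
compound 1 `Nc1ncnc2c1c(-c1cccc(O)c1)cn2[C@H]1C[C@@H](CO)C1`: 1300 nM
compound 2 `COC(=O)N[C@H]1CC[C@@H](n2cc(-c3ccc(Cl)c(N)c3)c3c(N)ncnc32)CC1`: 4600 nM
compound 3 `CC(=O)N1CCN([C@H]2C[C@@H](n3cc(-c4ccccc4O)c4c(N)ncnc43)C2)CC1`: > 10000 nM

Within the data shown here, compound 3 is the only member of the three carrying the acetylpiperazine on the cyclobutyl ring, and in this assay compound 3 returns no number at all, only a limit, > 10000 nM. It sits at the limit of > 10000 nM in this assay, at which 1 of the 3 values shown sits, so its true position relative to compound 1 and compound 2 is not known from these data.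

The next compound, compound 4 `CC(=O)N1CCN([C@H]2C[C@@H](n3cc(-c4ccc(Cl)c(O)c4)c4c(N)ncnc43)C2)CC1`, keeps everything of compound 3 apart from the aryl group. The change is 4-chloro-3-hydroxyphenyl in place of 2-hydroxyphenyl on an aromatic carbon. Among the measured compounds shown here, no pair among the measured compounds differs in this one place, so no measured step guides the size of the expected effect. Compound 1 carries a hydroxyl on the aryl ring in a pattern close to that entering in compound 4, and compound 2 carries the chlorine, yet both differ from compound 3 elsewhere, so their values show only that the two substituent patterns can be tolerated.

For this assay a step of an at least 1.4-fold lower number from compound 3 to compound 4 (0.15 log units; that floor lies within the scatter) is expected, a modest gain in the direction of stronger inhibition but likely within the scatter. Compound 4 is estimated at 7000 nM, with a range from 2000 nM to 25000 nM.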

Compound 4, half-maximal inhibitory concentration: 3700 nM
Compound 4: the middle estimate sits 1.9-fold (0.28 log units) above what was measured; the range from low to high includes it.
By their numbers in this assay, from the lowest: compound 1; then compounds 4 and 2 (each within the scatter of the next). At a limit, above all of these: compound 3.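

On the acetylpiperazine cyclobutyl series, the aromatic carbon of the five-membered ring responds to the choice of aryl group: in this assay, 4-chloro-3-hydroxyphenyl in place of 2-hydroxyphenyl gives an at least 2.7-fold lower number from compound 3 to compound 4 (0.43 log units; beyond the scatter). Among these compounds, this is the only measured step at this place, and it lies beyond the scatter, so with the acetylpiperazine held fixed the aryl substitution pattern matters here. The size of the step stands only as a floor, since the value of compound 3 is a limit and not a number: the limit of > 10000 nM in this assay, at which 1 of the 4 values shown sits.

The change brings in the chlorine and alters the hydroxyl pattern in one step, so the compounds shown do not separate the contribution of the chlorine from that of the hydroxyl pattern. Also open, going by these compounds, is whether an amine in place of the hydroxyl, or a fluorine or a methyl in place of the chlorine, would keep compound 4 at 3700 nM or shift the number beyond the scatter.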